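Swapping 4-methoxyphenyl for pyridin-2-yl on an amine nitrogen

The source may report more compounds than this note shows. Statements on the series, on what has been measured and on what is new or still open speak of the compounds shown alone.

Measured so far in a physicochemical assay for solubility, read by HPLC; on this read-out lower numbers stand for lower solubility and higher numbers for higher solubility

Compound 1 `COc1ccc(NC[C@@H](O)COc2ccc(N3C[C@H](CNC(C)=O)OC3=O)cc2F)cc1` gives 1300 nM
Compound 2 `CC(=O)NC[C@H]1CN(c2ccc(OC[C@@H](O)CNc3ccccn3)c(F)c2)C(=O)O1` gives 22200000 nM

Compound 1 holds the lower of the two numbers, and its gap to compound 2 lies well beyond the usual scatter of repeated measurements. The next compound to be measured is compound 3 `CC(=O)NC[C@H]1CN(c2ccc(OC[C@H](O)CNc3ccccn3)c(F)c2)C(=O)O1`. It has pyridin-2-yl in place of 4-methoxyphenyl on an amine nitrogen and otherwise matches compound 1. Going by the values given here, no single-change step between measured compounds is available to size this swap. The best guide is compound 2, which also carries pyridin-2-yl and gives 22200000 nM in this assay so a large rise beyond the scatter is expected. The estimated change is a 12000-fold higher number from compound 1 to compound 3 (4.06 log units; beyond the scatter) and it points upward. In this assay the estimate for compound 3 is 15000000 nM with an expected range of 4000000 nM to 50000000 nM around it.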

Compound 3, solubility: 35100000 nM
Compound 3: middle estimate off by 2.3-fold (0.37 log units), on the low side, and the stated range covers the measured number.
By their numbers in this assay, from the lowest: compound 1; then compounds 2 and 3 (each within the scatter of the next).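

In this assay, the swap of 4-methoxyphenyl for pyridin-2-yl on an amine nitrogen can now be sized directly, and it comes to a 27000-fold higher number from compound 1 to compound 3 (4.43 log units; beyond the scatter). The second step tests only the stereocentre at a saturated chain carbon, drawn S in compound 2 and R in compound 3, and it reads a 1.6-fold higher number from compound 2 to compound 3 (0.20 log units; within the scatter), which lies within the usual scatter. The large rise therefore goes with the swapped group, while the drawn configuration at that stereocentre leaves the number in the same range, a reading that rests on one point: the fact that compounds 2 and 3 differ only in the configuration as drawn.

As far as these compounds go, whether the rise comes from losing the methoxy group or from gaining the ring nitrogen stays open, and a plain phenyl on the same amine nitrogen would separate the two. Also open, from the compounds shown here alone, is how far the swap carries to other rings, such as pyrimidin-2-yl.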